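Adding a Hydroxy Group to Compound 2

The compounds below may be only part of what the source reports. "The series", "measured", "known", "first", "only" and "open" are said of these compounds alone.

Compound 1 `CN(C)CCCC(C)(O)c1ccc2ccccc2c1` gives 25 nM in an assay on membranes from brain for displacement of a labelled ligand from Sigma non-opioid intracellular receptor 1 (Cavia porcellus); a higher number here means a weaker inhibitor, a lower number a stronger inhibitor.
Compound 2 `CC(CCN(C)C)c1ccc2ccccc2c1` gives 1.95 nM in this assay.
Compound 3 `CC(CCN(C)C)c1cccc2ccccc12` gives 47.2 nM in this assay.

Compound 2 has the lowest number of the three, and both other compounds lie beyond the scatter from it, so it is the strongest inhibitor among them. Compound 4 `CC(CCN(C)C)c1ccc2cc(O)ccc2c1` differs from compound 2 in one place: hydroxy in place of hydrogen on an aromatic carbon. Among the compounds with values here, no pair of measured compounds shows this change, so its effect has not been seen directly; compound 1, which carries a hydroxy group elsewhere, gives 25 nM, and nothing more can be read from that. The expected step of a 2.6-fold higher number from compound 2 to compound 4 (0.41 log units; beyond the scatter) is small, towards a higher number, and close to the edge of the scatter. Compound 4 is estimated at 5 nM, with a range from 1.5 nM to 20 nM.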

Compound 4, inhibition constant: 19 nM
Compound 4: the middle estimate sits 3.8-fold (0.58 log units) below what was measured; low and high end bracket the measured number.
By their numbers in this assay, from the lowest: compound 2; then compounds 4, 1 and 3 (each within the scatter of the next, the first and the last beyond it).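

In this assay, within the data shown here, putting hydroxy in place of hydrogen on this aromatic carbon gives a 9.7-fold higher number from compound 2 to compound 4 (0.99 log units; beyond the scatter), so this change, now seen directly for the first time, clearly weakens the inhibitor. The single added oxygen is enough to cost compound 2 its lead at this position. Nothing measured here shows why the number rises.

As far as these compounds go, it remains open whether this loss belongs to hydroxy itself or would come with any group on this carbon. A methoxy group or an amine at the same place could separate those two readings.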